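Varying the Amine on a Shared Core: Predicting Compound 4

The source may hold more compounds than are shown below. What is called first, only, known or untested is meant among the compounds shown, and "the series" means these compounds.

Compound 1 `CCC(CC)Nc1nc(C)nc2c(-c3ccc(OC)nc3C)c(C)nn12` gives 3.1 nM in an assay on cell membranes for displacement of a labelled ligand from corticotropin-releasing factor receptor 1 (Rattus norvegicus); on this read-out higher numbers stand for weaker inhibition and lower numbers for stronger inhibition.
Compound 2 `CCCCN(CC)c1nc(C)nc2c(-c3ccc(OC)nc3C)c(C)nn12` gives 4.9 nM in this assay.
Compound 3 `CCCCN(C)c1nc(C)nc2c(-c3ccc(OC)nc3C)c(C)nn12` gives 8.1 nM in this assay.

Compound 3 carries the highest number of the three; a 1.7-fold higher number from compound 2 to compound 3 (0.22 log units; within the scatter) lies within the scatter, while a 2.6-fold higher number from compound 1 to compound 3 (0.42 log units; beyond the scatter) lies beyond it. Compound 4 `CCCN(CC1CC1)c1nc(C)nc2c(-c3ccc(OC)nc3C)c(C)nn12` differs from compound 3 by (cyclopropylmethyl)(propyl)amino in place of butyl(methyl)amino on an aromatic carbon. The steps among the amines measured so far bear on this change: a 1.6-fold higher number from compound 1 to compound 2 (0.20 log units; within the scatter) is small, and the step from compound 1 to compound 3 is only modest. With both substituents on the nitrogen growing in the same place, a small shift toward a lower number is expected for compound 4, a 1.6-fold lower number from compound 3 to compound 4 (0.21 log units; within the scatter). Compound 4 is therefore estimated at 5 nM in this assay, with a range from 2 nM to 12 nM.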

Compound 4, half-maximal inhibitory concentration: 1.6 nM
For compound 4 the middle estimate is 3.1-fold (0.49 log units) above the measured one; measured number outside the range, below it.
By their numbers in this assay, from the lowest: compounds 4, 1, 2 and 3 (each within the scatter of the next, the first and the last beyond it).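

On this aromatic carbon, (cyclopropylmethyl)(propyl)amino brings a 5.1-fold lower number from compound 3 to compound 4 (0.70 log units; beyond the scatter) and a 3.1-fold lower number from compound 2 to compound 4 (0.49 log units; beyond the scatter) in this assay on this read-out, a wider spread than the earlier amines showed. Set against (pentan-3-yl)amino it shows a 1.9-fold lower number from compound 1 to compound 4 (0.29 log units; within the scatter) and so stands level with that group, with two substituents on the nitrogen, one of them holding a three-membered ring. No measurement here explains these shifts. Open, going by these compounds, is whether the ring matters or only the added carbons: dipropylamino or bis(cyclopropylmethyl)amino on this carbon would separate the two.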